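The compounds below may be only part of what the source reports. "The series", "measured", "known", "first", "only" and "open" are said of these compounds alone.

Three glycosides built on a shared core were tested in a functional assay on A549 cells (Homo sapiens) for cytotoxicity, read by sulforhodamine B assay; a lower number here means a stronger inhibitor, a higher number a weaker inhibitor. Compound 1 `COc1cc([C@H]2Oc3c(OC)cc(CCCO)cc3[C@@H]2CO[C@@H]2O[C@@H](C)[C@H](O)[C@@H](O)[C@H]2O)cc(OC)c1O` gives only the limit of the assay, > 10000 nM, so no number is known for it. Compound 2 `COc1cc(C[C@H]2CO[C@@H](c3cc(OC)c(O)c(OC)c3)[C@H]2CO[C@@H]2O[C@@H](C)[C@H](O)[C@@H](O)[C@H]2O)cc(OC)c1O` likewise stops at the limit, > 10000 nM. Compound 3 `COc1cc(C[C@H](CO)[C@@H](CO[C@@H]2O[C@@H](C)[C@H](O)[C@@H](O)[C@H]2O)Cc2cc(OC)c(O)c(OC)c2)cc(OC)c1O` also reaches no number, sitting at > 10000 nM. Compound 1 therefore stands where every measured compound here stands: at the limit of > 10000 nM in this assay, at which 3 of the 3 values shown sit, with no measured potency that could be ranked against the others.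

Compound 4 `COc1cc([C@@H]2Oc3c(OC)cc(CCCO)cc3[C@H]2CO[C@@H]2O[C@@H](C)[C@H](O)[C@@H](O)[C@H]2O)cc(OC)c1O` has not yet been measured in this assay. Its change from compound 1 is this: the two compounds have the same atoms and bonds and differ only in configuration as drawn: 2 of 7 stereo elements differ; a stereocentre at a saturated ring carbon is drawn S in compound 1 and R in compound 4; a stereocentre at a saturated ring carbon is drawn R in compound 1 and S in compound 4. Among the compounds with values here, no step between two measured compounds is known, so the size of step to expect rests on the pattern of limits alone. Because compound 1, compound 2 and compound 3 all sit at the limit of > 10000 nM in this assay, at which 3 of the 3 values shown sit, and the change leaves the same atoms and bonds in place, compound 4 is expected to show no measurable inhibition either, with an expected step that the limit leaves unreadable from compound 1 to compound 4, that is, no change beyond the scatter and no direction. Compound 4 is accordingly estimated to give 20000 nM in this assay, within an expected range of 5000 nM to 100000 nM, most likely reported again as a limit rather than a number.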

Compound 4, half-maximal inhibitory concentration: > 10000 nM
Compound 4 was reported as a limit; the forecaster's own chance of this, stated with the estimate: 85%; the middle value does not contradict the limit.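

Compound 1 and compound 4 differ only in the configuration drawn at two saturated ring carbons, but no step between them can be read, since both results are limits and not numbers: the limit of > 10000 nM in this assay, at which 4 of the 4 values shown sit.

The compounds shown leave open whether any of them has a measurable potency in this assay, and so whether this change in configuration affects it.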